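An Ester Gives Way to a Methoxyphenyl Group

The source may report more compounds than this note shows. Statements on the series, on what has been measured and on what is new or still open speak of the compounds shown alone.

In a functional assay on PC-12 cells (Rattus norvegicus) for cytotoxicity, read by MTT assay, with stated times of 3 h and 2 h, tested at 1 uM (a higher number here means a stronger effect of the compound at the concentration tested, a lower number a weaker effect), compound 1 `O=C(CCCCC1CCSS1)NCc1cn(CCCCCOc2ccc3ccc(=O)oc3c2)nn1` gives 57.2%. Among the compounds with values here, compound 2 `CCOC(=O)c1cc2ccc(OCCCCCn3cc(CNC(=O)CCCCC4CCSS4)nn3)cc2oc1=O` carries an ethoxycarbonyl group where compound 1 has hydrogen, and in this assay compound 2 gives 35.1%, the lowest of the two numbers known so far; the change between them was a number 22.1 percentage points lower from compound 1 to compound 2 (beyond the scatter).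

The next compound, compound 3 `COc1ccc(-c2cc3ccc(OCCCCCn4cc(CNC(=O)CCCCC5CCSS5)nn4)cc3oc2=O)cc1`, differs from compound 2 in one place: 4-methoxyphenyl in place of ethoxycarbonyl on an aromatic carbon. Within the data shown here, no measured pair repeats this exact swap. Among the measured compounds shown here, the only step that touches the same aromatic carbon, a number 22.1 percentage points lower from compound 1 to compound 2 (beyond the scatter), shows that adding ethoxycarbonyl in place of hydrogen lowered the read-out by a modest amount, but it says nothing about how 4-methoxyphenyl compares with ethoxycarbonyl. For the measured compounds named here, with a single step of this kind and no direct precedent, the expected change is small and uncertain in direction, so the estimate for compound 3 is a step of a number 6.9 percentage points higher from compound 2 to compound 3 (within the scatter), which stays within the usual scatter. Compound 3 is therefore expected to give about 42% in this assay, with a plausible range from 25% to 60%.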

Compound 3, a percentage reported as activity, at one concentration (the size of the read-out at that concentration, not a potency): 37.1%
The estimate for compound 3 lay 4.9 percentage points above the measured number, and the stated range covers the measured number.
By their numbers in this assay, from the lowest: compounds 2 and 3 (each within the scatter of the next); then compound 1.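

In this assay, swapping ethoxycarbonyl for 4-methoxyphenyl on this aromatic carbon gives a number 2 percentage points higher from compound 2 to compound 3 (within the scatter), so a group with no ring and a group carrying a six-membered aromatic ring of carbon only cannot be told apart here, although the second has more heavy atoms. Compound 1 had previously been compared with only one substituent at this position, whereas the step of a number 20.1 percentage points lower from compound 1 to compound 3 (beyond the scatter) shows that a second, quite different group also gives a lower number than hydrogen, and by a modest amount. Within these three compounds, then, the main contrast is between hydrogen and either substituent, not between the two substituents, and no measurement at hand gives a reason for this result.

From the compounds shown here alone, it remains open whether a smaller group such as methyl, or an amine or a carboxylic acid, on the same aromatic carbon would give a number close to that of compound 1 or closer to those of compound 2 and compound 3. Going by these compounds, all three compounds also share the rest of their structure, so it is equally open whether this contrast would persist with a longer chain joining the two ends of the molecule.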